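A Chloro Substituent on the Aromatic Ring of Compound 1

The compounds below may be only part of what the source reports. "The series", "measured", "known", "first", "only" and "open" are said of these compounds alone.

Compound 1 `CCS(=O)(=O)Nc1cccc2c1CCCC2c1c[nH]cn1` was tested in an assay on isolated protein for binding affinity to Alpha-1A adrenergic receptor (Rattus norvegicus), read by radioligand binding (on this read-out higher numbers stand for weaker inhibition and lower numbers for stronger inhibition), where compound 1 gives 46.8 nM, the lowest of the two numbers shown. Compound 3 `CC(=O)Nc1cccc2c1CCCC2c1c[nH]cn1`, which carries acetyl in place of ethylsulfonyl on a nitrogen on an aromatic ring, gives 525 nM; that is an 11-fold higher number from compound 1 to compound 3 (1.05 log units; beyond the scatter). Compound 2 `CCS(=O)(=O)Nc1cccc2c1CCCC2(O)c1c[nH]cn1` has hydroxy in place of hydrogen on a saturated ring carbon. In this assay compound 2 gives only a limit, < 10000 nM. Hence a step that the limit leaves unreadable from compound 1 to compound 2. The new compound 4 `CCS(=O)(=O)Nc1cc(Cl)cc2c1CCCC2c1c[nH]cn1` differs from compound 1 by chloro in place of hydrogen on an aromatic carbon. For the measured compounds named here, neither measured step alters the aromatic carbons, so no measured step bears directly on this change; the expectation is a step within the scatter, in either direction. Compound 4 is therefore expected to give about 40 nM, between 12 nM and 150 nM, which corresponds to the estimated step of a 1.2-fold lower number from compound 1 to compound 4 (0.07 log units; within the scatter).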

Compound 4, inhibition constant: 45.7 nM
For compound 4 the middle estimate is 1.1-fold (0.06 log units) below the measured one, within the range that was stated.
By their numbers in this assay, from the lowest: compounds 4 and 1 (each within the scatter of the next); then compound 3.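

Chloro in place of hydrogen on this aromatic carbon, meta to a (ethylsulfonyl)amino group, gives a 1.0-fold lower number from compound 1 to compound 4 (0.01 log units; within the scatter) in this assay and so leaves the number unchanged within the scatter. The earlier steps shown here changed only the group on the nitrogen and a saturated ring carbon, whereas this one shows that the aromatic ring of the core of compound 1 can carry a chlorine atom at this position without a readable change. Nothing shown gives a cause for this result.

Going by these compounds, whether an amine, methoxy or a carboxylic acid on this same carbon would also leave the number unchanged remains open. So does whether chloro on the other aromatic carbons, or on the acetyl compound 3, would do the same.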